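The source may report more compounds than this note shows. Statements on the series, on what has been measured and on what is new or still open speak of the compounds shown alone.

Working notes on the series. In a functional assay on MCF7 cells (Homo sapiens) for antiproliferative activity, read by MTT assay, with a stated time of 72 h (on this read-out lower numbers stand for stronger inhibition and higher numbers for weaker inhibition), compound 1 (`Nc1nc(N)c2cc(CSC(=S)N3CCN(c4ccc(O)cc4)CC3)ccc2n1`) gives 5090 nM and compound 2 (`Cc1ccc(N2CCN(C(=S)SCc3ccc4nc(N)nc(N)c4c3)CC2)cc1`) gives 2480 nM while compound 3 (`Nc1nc(N)c2cc(CSC(=S)N3CCN(c4ccc(Cl)cc4)CC3)ccc2n1`) gives 4880 nM on the same read-out. Compound 3 therefore stands within the scatter of both other compounds.

The next compound is compound 4 (`Nc1nc(N)c2cc(CSC(=S)N3CCN(c4ccc(F)cc4)CC3)ccc2n1`), which differs from compound 3 in one place (fluoro in place of chloro on an aromatic carbon): fluoro in place of chloro on an aromatic carbon, para to a large group, that is, 4-chlorophenyl to 4-fluorophenyl.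

Among the measured compounds shown here, three measured steps bear on this same place. Chloro in place of hydroxy (a 1.0-fold lower number from compound 1 to compound 3 (0.02 log units; within the scatter)) and chloro in place of methyl (a 2.0-fold higher number from compound 2 to compound 3 (0.29 log units; within the scatter)) both stay within the scatter, while methyl in place of hydroxy (a 2.1-fold lower number from compound 1 to compound 2 (0.31 log units; beyond the scatter)) is the only step beyond it, and only modestly. For the measured compounds named here, no measured compound carries fluoro, so the data show no direction for this swap. With steps of this size at this place, no change beyond the scatter is expected in this assay for this swap.

The estimated step is small (a 1.1-fold lower number from compound 3 to compound 4 (0.05 log units; within the scatter)) and has no firm direction. For compound 4 the expected value is 4300 nM within an estimated range of 2400 nM to 7500 nM on this read-out.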

Compound 4, half-maximal inhibitory concentration: 1920 nM
For compound 4 the middle estimate is 2.2-fold (0.35 log units) above the measured one; the measured number lies below the stated range.
By their numbers in this assay, from the lowest: compounds 4, 2, 3 and 1 (each within the scatter of the next, the first and the last beyond it).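

In this assay, among the compounds shown here, the change from 4-chlorophenyl to 4-fluorophenyl shows that the identity of the halogen at this place can move the read-out beyond the scatter (a 2.5-fold lower number from compound 3 to compound 4 (0.41 log units; beyond the scatter)), a step that the earlier compounds, none of which carried fluoro, could not show. Fluoro also separates from hydroxy (a 2.7-fold lower number from compound 1 to compound 4 (0.42 log units; beyond the scatter)) but not from methyl (a 1.3-fold lower number from compound 2 to compound 4 (0.11 log units; within the scatter)), so the four compounds now fall into a pair carrying fluoro and methyl and a pair carrying chloro and hydroxy, although the step from methyl to chloro itself stays within the scatter. Nothing available explains why fluoro and chloro differ here.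

The substituents shown at this place are limited to hydroxy, methyl, chloro and fluoro, so it remains open how a methoxy group, an amine, a trifluoromethyl group or a carboxylic acid would compare with fluoro. From the compounds shown here alone, it also remains open whether the step from chloro to fluoro would hold with fluoro elsewhere on the ring or with a change in the shared core.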